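From One Inactive Compound to an Untested Relative

A few compounds are considered here, and "the series" means these few. Any claim that something is new, unique, unknown or untested is made for them only; others in the source may bear on it.

Compound 1 `Cc1cc(C)cc(-n2nncc2CN2C(=O)C3(C(C#N)=C(N)Oc4c3c3nc5ccccc5nc3c3ccccc43)c3ccccc32)c1` and compound 2 `COc1ccc(-n2nncc2CN2C(=O)C3(C(C#N)=C(N)Oc4c(N)cc5nc6ccccc6nc5c43)c3ccccc32)cc1` share the same large core and differ in the group carried on an aromatic nitrogen of a five-membered aromatic ring with 3 nitrogen. In a functional assay on HCT-116 cells (Homo sapiens) for antiproliferative activity, read by MTT assay, with a stated time of 48 h (on this read-out lower numbers stand for stronger inhibition and higher numbers for weaker inhibition), compound 1 gives only a limit, > 50000 nM. In this assay compound 2 likewise gives only a limit, > 50000 nM. Among the compounds with values here, neither compound has a true number, since both sit at the limit of > 50000 nM in this assay, at which 2 of the 2 values shown sit, so compound 2 stands level with the only other measured compound and no ordering between the two can be drawn.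

Compound 3 `N#CC1=C(N)Oc2c(N)cc3nc4ccccc4nc3c2C12C(=O)N(Cc1cnnn1-c1ccc(Cl)cc1[N+](=O)[O-])c1ccccc12` is the untested relative. It comes from compound 2 through one change, (4-chloro-2-nitrophenyl in place of 4-methoxyphenyl on an aromatic nitrogen). Within the data shown here, no step between measured compounds is available, so the effect of such a change cannot be read from these data. The step of a number no higher from compound 2 to compound 3 (the limit leaves the size open) is expected to be none beyond the usual scatter. Compound 3 is therefore estimated to give 50000 nM in this assay, within a range from 20000 nM to 100000 nM, most likely again reported only as a limit.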

Compound 3, half-maximal inhibitory concentration: 28700 nM
Compound 3: the middle estimate sits 1.7-fold (0.24 log units) above what was measured; measured number inside the range.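

In this assay compound 3 gives 28700 nM, a true number, so the group on the aromatic nitrogen of the five-membered ring can bring a compound of this family to a reading the assay can report. Putting 4-chloro-2-nitrophenyl in place of 4-methoxyphenyl gives an at least 1.7-fold lower number from compound 2 to compound 3 (0.24 log units; that floor lies within the scatter), and this is only a floor: the real step may be larger, but the floor alone does not set it apart from ordinary repeat variation. The real size of the step stays unknown because compound 2 has no true number of its own: the limit of > 50000 nM in this assay, at which 2 of the 3 values shown sit.

The chlorine and the nitro group enter together, and the compounds shown do not separate what each contributes to the step. They also leave open how a phenyl ring carrying only a chlorine, only a nitro group, or an amine or a carboxylic acid instead would read in this assay.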